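A few compounds are considered here, and "the series" means these few. Any claim that something is new, unique, unknown or untested is made for them only; others in the source may bear on it.

Measured so far in an ADME assay on BCBL1 cells (Homo sapiens) for cytotoxicity, with a stated time of 7 days; on this read-out lower numbers stand for higher toxicity in this test and higher numbers for lower toxicity in this test:
compound 1, `CCCCCCCCOc1nc(N)nc2c1ncn2/C=C1/CC1(CO)CO`: > 20000 nM
compound 2, `Nc1nc(NC2CCCCC2)c2ncn(/C=C3/CC3(CO)CO)c2n1`: > 20000 nM
compound 3, `CCCSc1nc(N)nc2c1ncn2/C=C1/CC1(CO)CO`: > 20000 nM

Compound 3 stands at a limit of this assay, not at a number, with > 20000 nM. Compound 1 likewise stands at a limit, > 20000 nM. Compound 2 also stands at a limit, > 20000 nM. All three values share (the limit of > 20000 nM in this assay, at which 3 of the 3 values shown sit), so the series gives no readable spread.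

Compound 4, `CN(C)c1nc(N)nc2c1ncn2/C=C1/CC1(CO)CO`, differs from compound 3 by dimethylamino in place of propylsulfanyl on an aromatic carbon. The steps that touch the same aromatic carbon, a step that the two limits leave unreadable from compound 1 to compound 3 and a step that the two limits leave unreadable from compound 2 to compound 3, are both unreadable in size, so no direction beyond the scatter can be read for the new change. Compound 4 is therefore expected to stay at the limit, estimated at 20000 nM, range 10000 nM to 40000 nM. The expected step is a number no higher from compound 3 to compound 4 (the limit leaves the size open).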

Compound 4, half-maximal cytotoxic concentration: > 20000 nM
Compound 4 gave a limit, no number (the forecaster's own chance of this, stated with the estimate: 85%); the middle value sits exactly at the limit.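

No step can be read between compound 4 and compound 1, compound 2 or compound 3, because each value is a limit: the limit of > 20000 nM in this assay, at which 4 of the 4 values shown sit. The compounds shown leave open how these aromatic-carbon groups rank for toxicity in this test.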